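This account rests on a few compounds, and the source may have more. Where it says the series, first, only, none or still open, it means among the compounds named here.

Measured in a functional assay on K562 cells (Homo sapiens) for inhibition, read by sulforhodamine B assay, with a stated time of 48 h; a lower number here means a stronger inhibitor of growth, a higher number a weaker inhibitor of growth:
compound 1 `O=C(Nc1cccc(-n2cc(-c3ccncc3)c(-c3ccc(Cl)c(O)c3)n2)c1)Nc1cccc(C(F)(F)F)c1` — 1440 nM
compound 2 `COc1cc(-c2nn(-c3cccc(NC(=O)Nc4cc(C(F)(F)F)cc(C(F)(F)F)c4)c3)cc2-c2ccncc2)ccc1Cl` — 363 nM
compound 3 `COc1cc(-c2nn(-c3cccc(NC(=O)Nc4cccc(C(F)(F)F)c4)c3)cc2-c2ccncc2)ccc1Cl` — 584 nM

Compound 2 has the lowest number of the three in this assay, but the step of a 1.6-fold higher number from compound 2 to compound 3 (0.21 log units; within the scatter) lies within the scatter, so compound 2 and compound 3 cannot be ordered against each other; only compound 1 stands clearly apart from compound 2. Compound 4 `O=C(Nc1cccc(-n2cc(-c3ccncc3)c(-c3ccc(Cl)c(O)c3)n2)c1)Nc1cc(C(F)(F)F)cc(C(F)(F)F)c1` differs from compound 2 in one place: hydrogen in place of methyl on an oxygen on an aromatic ring. The same change, run the other way, is seen in the step of a 2.5-fold lower number from compound 1 to compound 3 (0.39 log units; beyond the scatter), which is beyond the scatter. The difference between compound 2 and compound 3 is a different change and does not bear on this step. Reversing the step between compound 1 and compound 3 gives the expectation that the number in this assay rises beyond the scatter by about the same size. For compound 4 the expected step is a 2.5-fold higher number from compound 2 to compound 4 (0.39 log units; beyond the scatter). Compound 4 is therefore estimated at 900 nM, with a range of 450 nM to 1800 nM.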

Compound 4, concentration for 50% growth inhibition: 433 nM
Beside the measured number, compound 4's estimate is 2.1-fold (0.32 log units) above it; the measured number lies below the stated range.
By their numbers in this assay, from the lowest: compounds 2, 4 and 3 (each within the scatter of the next); then compound 1.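

In this assay, methoxy to hydroxy on the core carrying the added trifluoromethyl gives a 1.2-fold higher number from compound 2 to compound 4 (0.08 log units; within the scatter), whereas on the other core the same change was a step beyond the scatter. The two readings of this change do not differ beyond the scatter, so the data do not establish that the core alters it: the same change on two cores in this assay, a 2.5-fold lower number (0.39 log units; beyond the scatter) from compound 1 to compound 3 and a 1.2-fold lower number (0.08 log units; within the scatter) from compound 4 to compound 2, 2.1-fold (0.32 log units) apart, within the scatter of two such steps. Seen from the hydroxy side, trifluoromethyl in place of hydrogen on an aromatic carbon gives a 3.3-fold lower number from compound 1 to compound 4 (0.52 log units; beyond the scatter), a step beyond the scatter where the methoxy pair stayed within it, though the gap between these two steps is also within the scatter: the same change on two cores in this assay, a 1.6-fold higher number (0.21 log units; within the scatter) from compound 2 to compound 3 and a 3.3-fold higher number (0.52 log units; beyond the scatter) from compound 4 to compound 1, 2.1-fold (0.32 log units) apart, within the scatter of two such steps.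

As far as these compounds go, it remains open how an amine or a longer chain such as ethoxy in place of methoxy on this ring would read. From the compounds shown here alone, it also remains open whether a nitrile or a chlorine in place of the added trifluoromethyl would give a similar step.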